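The source may report more compounds than this note shows. Statements on the series, on what has been measured and on what is new or still open speak of the compounds shown alone.

Compound 1 `CC1CC/C(=N\Nc2cccc(I)c2)c2ncc(C(=O)O)c(=O)n21` gives 1000 umol/kg in a functional assay on the whole organism for inhibition, with Rattus norvegicus as the target; a lower number here means that less compound is needed, a higher number that more compound is needed for the effect. Compound 2 `CC1CC/C(=N\Nc2ccccc2O)c2ncc(C(=O)O)c(=O)n21` shows in this assay only a limit, > 100 umol/kg, not a number. The step that the limit leaves unreadable from compound 1 to compound 2 therefore cannot be read, as the limit of > 100 umol/kg in this assay, at which 1 of the 2 values shown sits, shows. Among the compounds with values here, compound 3 `Cc1cccc(N/N=C2\CCC(C)n3c2ncc(C(=O)O)c3=O)c1` differs from compound 2 as follows: 3-methylphenyl in place of 2-hydroxyphenyl on an amine nitrogen Only that unreadable step bears on the change, so no direction in this assay is fixed beyond the scatter. Within the data shown here, the step that the limit leaves unreadable from compound 2 to compound 3 is expected only loosely, because compound 1 gives 1000 umol/kg as the single readable number. Compound 3 is estimated at 700 umol/kg in this assay, with a range from 150 umol/kg to 3000 umol/kg.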

Compound 3, dose for 50% inhibition: 72.5 umol/kg
For compound 3 the middle estimate is 9.7-fold (0.98 log units) above the measured one, outside the stated range (below it).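

In this assay, within the data shown here, methyl in place of iodo on an aromatic carbon gives a 14-fold lower number from compound 1 to compound 3 (1.14 log units; beyond the scatter), the first readable step and one beyond the scatter. Against 2-hydroxyphenyl on the amine nitrogen, 3-methylphenyl gives an at least 1.3-fold lower number from compound 2 to compound 3 (0.13 log units; that floor lies within the scatter), so this comparison fixes no direction beyond the scatter. The step between compound 1 and compound 2 cannot be read: the limit of > 100 umol/kg in this assay, at which 1 of the 3 values shown sits.

Still open, from the compounds shown here alone, is the actual number for compound 2, which has only a limit. Also open, going by these compounds, is whether chloro or methoxy in place of methyl on that aromatic carbon would hold the number seen for compound 3.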